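Sulfide and sulfone pair: trifluoromethyl position

This account rests on a few compounds, and the source may have more. Where it says the series, first, only, none or still open, it means among the compounds named here.

Measured compounds:
compound 1 `CC(O)(CSc1cccc(C(F)(F)F)c1)C(=O)Nc1ccc(S(F)(F)(F)(F)F)cc1` — in a functional assay on VCaP cells (Homo sapiens) for antiproliferative activity, read by propidium iodide staining, with a stated time of 96 h (a higher number here means a weaker inhibitor, a lower number a stronger inhibitor), compound 1 gives 18800 nM
compound 2 `CC(O)(CSc1ccccc1C(F)(F)F)C(=O)Nc1ccc(S(F)(F)(F)(F)F)cc1` — compound 2 gives 21000 nM
compound 3 `CC(O)(CS(=O)(=O)c1cccc(C(F)(F)F)c1)C(=O)Nc1ccc(S(F)(F)(F)(F)F)cc1` — compound 3 gives 32000 nM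

The difference between the core of compound 1 and the core of compound 3 is not broken down here. Within the first pair the change 2-(trifluoromethyl)phenyl in place of 3-(trifluoromethyl)phenyl on a sulfur gave a 1.1-fold higher number from compound 1 to compound 2 (0.05 log units; within the scatter). Compound 4 `CC(O)(CS(=O)(=O)c1ccccc1C(F)(F)F)C(=O)Nc1ccc(S(F)(F)(F)(F)F)cc1` is not yet measured; it differs from compound 3 by 2-(trifluoromethyl)phenyl in place of 3-(trifluoromethyl)phenyl on a sulfonyl sulfur. The place differs: on a sulfonyl sulfur whose other neighbours are saturated chain carbon, rather than on a sulfur whose other neighbours are saturated chain carbon, so this is the same kind of change, not the same one. Expected for compound 4 is a 1.1-fold higher number from compound 3 to compound 4 (0.04 log units; within the scatter), resting on the step of a 1.1-fold higher number from compound 1 to compound 2 (0.05 log units; within the scatter) and on compound 3 at 32000 nM. Compound 4 is estimated at 35000 nM, between 17000 nM and 70000 nM.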

Compound 4, half-maximal inhibitory concentration: 23800 nM
Compound 4: middle estimate off by 1.5-fold (0.17 log units), on the high side; the range from low to high includes it.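

Within the sulfone pair, 2-(trifluoromethyl)phenyl in place of 3-(trifluoromethyl)phenyl on a sulfonyl sulfur gives a 1.3-fold lower number from compound 3 to compound 4 (0.13 log units; within the scatter) in this assay. Set beside the same change on the sulfide pair, the two steps do not differ: the same change on two cores in this assay, a 1.1-fold higher number (0.05 log units; within the scatter) from compound 1 to compound 2 and a 1.3-fold lower number (0.13 log units; within the scatter) from compound 3 to compound 4, 1.5-fold (0.18 log units) apart, within the scatter of two such steps. This shows that the change has no readable effect on either core in this assay, but it does not show that a real effect would carry over, since neither step rises above the scatter and two pairs set no rule for other cores.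

Open, from the compounds shown here alone, is whether a nitrile or a chlorine in place of trifluoromethyl would move the value on either core. Also open, going by these compounds, is how an oxygen or an amine in place of the sulfur would read.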